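The source may hold more compounds than are shown below. What is called first, only, known or untested is meant among the compounds shown, and "the series" means these compounds.

Compound 1 `O=[N+]([O-])c1cccc(NS(=O)(=O)c2ccc(Cl)cc2)c1` — 7.51
Compound 2 `O=[N+]([O-])c1cccc(NS(=O)(=O)c2ccc(Br)cc2)c1` — 7.42
Compound 3 `O=S(=O)(Nc1ccc(F)cc1)c1ccc(Cl)cc1` — 8.41

Of the compounds shown here, three have been measured in an ADME assay. Compound 1 gives 7.51 and compound 2 gives 7.42. The change between them is bromo in place of chloro on an aromatic carbon, and the step it made was a number 0.09 log units lower from compound 1 to compound 2 (within the scatter). Compound 3 stands highest of the three numbers with 8.41; the difference between its core and the core of compound 1 is not broken down here.

Compound 4 `O=S(=O)(Nc1ccc(F)cc1)c1ccc(Br)cc1` has not yet been measured in this assay. It differs from compound 3 by bromo in place of chloro on an aromatic carbon, the same change as between compound 1 and compound 2. Because the earlier step was a number 0.09 log units lower from compound 1 to compound 2 (within the scatter), a similarly small step is expected here, a number 0.09 log units lower from compound 3 to compound 4 (within the scatter). Compound 4 is therefore estimated at 8.32, with the expected range running from 8 to 8.65.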

Compound 4, acid dissociation constant: 8.38
Compound 4: the middle estimate sits 0.06 log units below what was measured, within the range that was stated.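

In this assay, bromo in place of chloro on an aromatic carbon gave a number 0.03 log units lower from compound 3 to compound 4 (within the scatter). Set beside the earlier step, the same change behaved alike on both cores: the same change on two cores in this assay, a number 0.09 log units lower (within the scatter) from compound 1 to compound 2 and a number 0.03 log units lower (within the scatter) from compound 3 to compound 4, 0.06 log units apart, within the scatter of two such steps This supports carrying the swap between these two cores as a step within the scatter, but it says nothing about a third core and does not show how a step beyond the scatter would carry over.

The compounds shown leave open how the number responds when the chloro or bromo gives way to a group of another kind, such as a methoxy, an amine or a carboxylic acid. They also leave open whether such a replacement would behave alike on both cores.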